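This account rests on a few compounds, and the source may have more. Where it says the series, first, only, none or still open, it means among the compounds named here.

Series notes. The shared core of compound 1 `Cn1ncc(Cl)c1-c1cc(C(=O)N[C@@H]2CN[C@H](CC(=O)O)C[C@H]2c2ccc(Cl)c(Cl)c2)oc1Cl` carries a carboxy on a saturated chain carbon bound to a saturated ring carbon; in an assay for inhibition of RAC-alpha serine/threonine-protein kinase (Homo sapiens), read by HTRF, with a stated time of 1 h (a higher number here means a weaker inhibitor, a lower number a stronger inhibitor), compound 1 gives 1.94 nM. Compound 2 `Cn1ncc(Cl)c1-c1cc(C(=O)N[C@@H]2CN[C@H](CCN3CCCC3)C[C@H]2c2ccc(Cl)c(Cl)c2)oc1Cl` gives 6.41 nM, and compound 3 `COCC[C@@H]1C[C@@H](c2ccc(Cl)c(Cl)c2)[C@H](NC(=O)c2cc(-c3c(Cl)cnn3C)c(Cl)o2)CN1` gives 7.01 nM. Compound 3 has the highest number of the three, with compound 2 within the scatter of it and compound 1 the furthest from it. The recorded steps are a 3.3-fold higher number from compound 1 to compound 2 (0.52 log units; beyond the scatter); a 3.6-fold higher number from compound 1 to compound 3 (0.56 log units; beyond the scatter); and a 1.1-fold higher number from compound 2 to compound 3 (0.04 log units; within the scatter).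

Compound 4 `Cn1ncc(Cl)c1-c1cc(C(=O)N[C@@H]2CN[C@H](CC(=O)NCC(O)CO)C[C@H]2c2ccc(Cl)c(Cl)c2)oc1Cl` differs from compound 3 as follows.
(2,3-dihydroxypropyl)carbamoyl in place of methoxymethyl on a saturated chain carbon bound to a saturated ring carbon

The entering group is an amide built on the carboxy present in compound 1, so the step that bears most directly on this change is a 3.6-fold higher number from compound 1 to compound 3 (0.56 log units; beyond the scatter), which runs in the opposite direction; the step of a 1.1-fold higher number from compound 2 to compound 3 (0.04 log units; within the scatter) adds that two groups without a carboxy sit within the scatter of each other. For the measured compounds named here, no measured analogue carries a carbamoyl, so the expectation is loose. A modest move towards a lower number is expected, landing between the numbers of compound 1 and compound 3. For compound 4 the expected step is a 2.0-fold lower number from compound 3 to compound 4 (0.30 log units; within the scatter). Compound 4 is estimated at 3.5 nM, within the range 1.5 nM to 9 nM.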

Compound 4, half-maximal inhibitory concentration: 3.13 nM
For compound 4 the middle estimate is 1.1-fold (0.05 log units) above the measured one; the range from low to high includes it.
By their numbers in this assay, from the lowest: compounds 1 and 4 (each within the scatter of the next); then compounds 2 and 3 (each within the scatter of the next).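

At the saturated chain carbon bound to a saturated ring carbon, (2,3-dihydroxypropyl)carbamoyl is the only replacement for the carboxy of compound 1 shown here that stays within the scatter of it, with a 1.6-fold higher number from compound 1 to compound 4 (0.21 log units; within the scatter) in this assay, so this larger group, with its 8 heavy atoms and 3 hydrogen-bond donors, is accepted at this position. Against the two groups without a carbonyl on this carbon, the step to compound 4 from methoxymethyl is a 2.2-fold lower number from compound 3 to compound 4 (0.35 log units; beyond the scatter) and the one from (pyrrolidin-1-yl)methyl is a 2.0-fold lower number from compound 2 to compound 4 (0.31 log units; beyond the scatter), both modest but beyond the scatter, so among these four compounds a carbonyl at this place goes with the lower numbers, and none of the four goes against that. No independent measurement is available to explain this pattern.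

On these data alone, it remains open whether the carbonyl alone accounts for the difference, or whether the 2,3-dihydroxypropyl part on the amide nitrogen also contributes. A plain primary carboxamide or a methyl ester at the same place would help separate the two, and an N-methyl amide would test the amide hydrogen.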